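A few compounds are considered here, and "the series" means these few. Any claim that something is new, unique, unknown or untested is made for them only; others in the source may bear on it.

In a functional assay on U2OS cells (Homo sapiens) for antiproliferative activity, read by MTT assay, with a stated time of 72 h (a lower number here means a stronger inhibitor, a higher number a weaker inhibitor), compound 1, with the structure `O=C(CSc1ncccn1)Nc1ccc2nc(NC(=O)c3ccc(C(F)(F)F)cc3)sc2c1`, gives 28100 nM. Among the compounds with values here, that is the only number in this assay among the three measured compounds; the other two sit at the limit of > 100000 nM in this assay, at which 2 of the 3 values shown sit. Compound 2, with the structure `Cc1cc(C)cc(C(=O)Nc2nc3ccc(NC(=O)CSc4ccc(Cl)cc4)cc3s2)c1`, reaches only the limit of this assay at > 100000 nM. Compound 3, with the structure `CC(O)c1cccc(NC(=O)c2cc(Br)ccc2Br)c1`, likewise reaches only the limit of this assay at > 100000 nM. So compound 1 stands alone with a measured value, and no pair of measured compounds differs in a single place, leaving no measured step to lean on.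

Compound 4, with the structure `O=C(CSc1cccc(O)c1)Nc1ccc2nc(NC(=O)c3ccc(C(F)(F)F)cc3)sc2c1`, is the next candidate. It differs from compound 1 as follows: 3-hydroxyphenyl in place of pyrimidin-2-yl on a sulfur. The shared core, the amide links and the trifluoromethyl-bearing aryl amide all stay as they are in compound 1.

With no measured step of this kind in hand, the author expects no change from compound 1 to compound 4 that would go beyond the scatter in this assay, the step of a 1.1-fold higher number from compound 1 to compound 4 (0.03 log units; within the scatter) being a guess held close to the only number known. Compound 4 is therefore estimated at 30000 nM, within a range from 10000 nM to 100000 nM.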

Compound 4, half-maximal inhibitory concentration: 630 nM
Beside the measured number, compound 4's estimate is 48-fold (1.68 log units) above it; the measured number lies below the stated range.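

In this assay, putting 3-hydroxyphenyl in place of pyrimidin-2-yl on a sulfur gives a 45-fold lower number from compound 1 to compound 4 (1.65 log units; beyond the scatter), while the shared core, the amide links and the trifluoromethyl-bearing aryl amide stay the same. Within the data shown here, this is the first single-place comparison, and it shows that the aromatic ring on this sulfur can by itself move the number well beyond the scatter. The change swaps a ring with 2 hetero atoms and 0 hydrogen-bond donors for a ring of carbon only with 1 hydrogen-bond donor, but nothing available explains why the step is so large.

The compounds shown leave open whether the step belongs to the hydroxyl or to the carbon-only ring, a question on which plain phenyl, 3-methoxyphenyl or 3-aminophenyl on the same sulfur would bear. They also leave open whether the sulfur itself matters, which an oxygen or a methylene in its place would test, and whether a carboxylic acid on the ring would be tolerated.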